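An ester gives way to a phenylsulfonyl group

The compounds below may be only part of what the source reports. "The series", "measured", "known", "first", "only" and "open" are said of these compounds alone.

Compound 1, `O=C(OC1CCC(CN2CCN(c3cc(=O)c4cc(C(F)(F)F)cc([N+](=O)[O-])c4s3)CC2)CC1)c1ccccc1`, in an ADME assay on Vero cells (Chlorocebus sabaeus) for cytotoxicity, read by MTT assay, with a stated time of 48 h; a lower number here means a stronger inhibitor, a higher number a weaker inhibitor: > 64 ug/mL
Compound 2, `O=C(OC1CCC(CN2CCN(c3cc(=O)c4cc(C(F)(F)F)cc([N+](=O)[O-])c4s3)CC2)CC1)c1ccc2c(c1)OCC2`, in this assay: > 64 ug/mL

Both numbers are limits of the assay, not measured values. Compound 2 therefore stands at the edge of what this assay can report, together with the only other compound shown: the limit of > 64 ug/mL in this assay, at which 2 of the 2 values shown sit. Going by the values given here, the one step between measured compounds, a step that the two limits leave unreadable from compound 1 to compound 2, tells nothing about size, since two limits cannot be compared.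

Compound 3, `O=c1cc(N2CCN(CC3CCC(OS(=O)(=O)c4ccccc4)CC3)CC2)sc2c([N+](=O)[O-])cc(C(F)(F)F)cc12`, changes the same part of the molecule once more: a group of 9 heavy atoms (6 carbon, 2 oxygen, 1 sulfur; one six-membered aromatic ring of carbon only) in place of a group of 11 heavy atoms (9 carbon, 2 oxygen; one five-membered non-aromatic ring with 1 hetero atom, one six-membered aromatic ring of carbon only), on an oxygen on a saturated carbon. Among the compounds with values here, the only step that could bear on this change is the one from compound 1 to compound 2, and it is unreadable. Within the data shown here, nothing in the numbers so far points to a step in either direction, so no step beyond the scatter is expected in this assay, and a limit is the most likely outcome again. Compound 3 is expected to give about 64 ug/mL, somewhere between 32 ug/mL and 128 ug/mL. The step this estimate means, a number no higher from compound 2 to compound 3 (the limit leaves the size open), is expected to be none beyond the scatter.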

Compound 3, half-maximal inhibitory concentration: > 64 ug/mL
Compound 3: no number, only a limit (the forecaster's own chance of this, stated with the estimate: 75%); the middle value lies on the limit itself.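

No step can be read from compound 1 or compound 2 to compound 3, because all three compounds end at a limit of this assay and not at a number: the limit of > 64 ug/mL in this assay, at which 3 of the 3 values shown sit.

The compounds shown leave open how far apart these three truly lie, and whether phenylsulfonyl in place of benzoyl makes any difference in this assay.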